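From allyl to propargyl: a small swap on compound 2

The source may hold more compounds than are shown below. What is called first, only, known or untested is meant among the compounds shown, and "the series" means these compounds.

Measured in a functional assay on SK-OV-3 cells (Homo sapiens) for cytotoxicity, read by MTT assay, with a stated time of 24 h; a higher number here means a weaker inhibitor, a lower number a stronger inhibitor:
- Compound 1 `C#CCn1c(=O)c(C=O)cc2cc(OC)ccc21`: > 100000 nM (a limit of the assay, not a number)
- Compound 2 `C=CCn1c(=O)c(/C=C/C(=O)/C=C(O)/C=C/c2ccc(O)c(OC)c2)cc2ccccc21`: 26000 nM

The entry for compound 1 is a limit. For the measured compounds named here, that leaves compound 2, at 26000 nM, with the only actual number in this assay. Compound 3 `C#CCn1c(=O)c(/C=C/C(=O)/C=C(O)/C=C/c2ccc(O)c(OC)c2)cc2ccccc21` differs from compound 2 by one small change ethynyl in place of vinyl on a saturated chain carbon bound to an aromatic nitrogen. Going by the values given here, no measured pair shows this swap, so no direction can be favoured. The expected step of a 1.1-fold lower number from compound 2 to compound 3 (0.03 log units; within the scatter) stays within the usual scatter. Compound 3 is estimated at 24000 nM, with an expected range of 9000 nM to 65000 nM.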

Compound 3, half-maximal inhibitory concentration: 19000 nM
Compound 3: middle estimate off by 1.3-fold (0.10 log units), on the high side, within the range that was stated.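

In this assay, for the compounds shown here, the change from allyl to propargyl gives a 1.4-fold lower number from compound 2 to compound 3 (0.14 log units; within the scatter) and this is the first direct look at the swap at this position. The two compounds read as equal here, so replacing vinyl with ethynyl leaves the cytotoxicity reading unchanged within normal scatter. Nothing at hand explains why this step has the size it has.

As far as these compounds go, what remains open is whether this position responds to a larger change. An amine or a longer chain on the saturated chain carbon bound to an aromatic nitrogen could behave quite differently.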